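Furan-bearing ester replaces a branched alkenyl ester

The compounds below may be only part of what the source reports. "The series", "measured", "known", "first", "only" and "open" are said of these compounds alone.

Three dihydropyridine esters have been measured:
compound 1 `CCCCC1=C(C(=O)OCC)C(c2cccc([N+](=O)[O-])c2)C(C(=O)OCC)=C(C)N1` 20 nM
compound 2 `CCOC(=O)C1=C(C)NC(COC)=C(C(=O)OC)C1c1cccc([N+](=O)[O-])c1` 14 nM
compound 3 `C=C(C)CCOC(=O)C1=C(C)NC(C)=C(C(=O)OC)C1c1cccc([N+](=O)[O-])c1` 23 nM

In a functional assay on HEK293 cells for antagonist activity at Voltage-dependent L-type calcium channel subunit alpha-1C (Oryctolagus cuniculus), read by FLIPR (a lower number here means a stronger inhibitor, a higher number a weaker inhibitor), compound 3 gives 23 nM, the highest of the three numbers, yet its gaps to compound 1 and compound 2 both fall within the usual scatter, so the three compounds cannot be ranked against one another.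

Compound 4 `COC(=O)C1=C(C)NC(C)=C(C(=O)OCc2ccco2)C1c1cccc([N+](=O)[O-])c1` has not been measured. It differs from compound 3 in one place: furan-2-yl in place of 2-methylprop-2-en-1-yl on a saturated chain carbon bound to an oxygen next to a carbonyl group. The change sits on a saturated chain carbon bound to an oxygen next to a carbonyl group.

Since the measured ester variations here all land close together, the step from compound 3 to compound 4 is expected to be small, a 1.2-fold lower number from compound 3 to compound 4 (0.06 log units; within the scatter), with no direction beyond the scatter. Compound 4 is therefore estimated at 20 nM, within 7 nM to 60 nM.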

Compound 4, half-maximal inhibitory concentration: 20 nM
Compound 4: the middle estimate sits on the measured number at the digits printed; the measured number falls inside the stated range.
By their numbers in this assay, from the lowest: compounds 2, 1, 4 and 3 (each within the scatter of the next).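

In this assay, putting furan-2-yl in place of 2-methylprop-2-en-1-yl on a saturated chain carbon bound to an oxygen next to a carbonyl group gives a 1.2-fold lower number from compound 3 to compound 4 (0.06 log units; within the scatter). For the compounds shown here, this is the first pair here that differs in one place, and it shows that a five-membered aromatic ring with one hetero atom can stand at this spot without a step beyond the scatter. No measurement at hand offers an explanation for this result. Still open, going by these compounds, is whether an amine, a carboxylic acid or a longer chain at this place would also stay within the scatter.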